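Replacing methylsulfanyl on the core of compound 3

A few compounds are considered here, and "the series" means these few. Any claim that something is new, unique, unknown or untested is made for them only; others in the source may bear on it.

Measured in a functional assay on the whole organism for antagonist activity, with Mus musculus as the target; on this read-out lower numbers stand for an effect already at smaller amounts and higher numbers for an effect only at larger amounts of compound:
- Compound 1 `Cn1c(-c2ccccc2)nnc1[S+](C)[O-]`: 18.6 mg/kg
- Compound 2 `CCS(=O)(=O)c1nnc(-c2ccccc2)n1C`: 19.3 mg/kg
- Compound 3 `CSc1nnc(-c2cccc3ccccc23)n1C`: > 200 mg/kg

Compound 3 has no number on this read-out and stands at the limit of > 200 mg/kg in this assay, at which 1 of the 3 values shown sits. Compound 4 `Cn1c(-c2cccc3ccccc23)nnc1[S+](C)[O-]` keeps the core of compound 3 but loses its methylsulfanyl group, and the change is a group of 3 heavy atoms (1 carbon, 1 oxygen, 1 sulfur; no ring) in place of a group of 2 heavy atoms (1 carbon, 1 sulfur; no ring), on an aromatic carbon. Going by the values given here, only one measured step touches this place, a 1.0-fold higher number from compound 1 to compound 2 (0.02 log units; within the scatter), and it stays within the scatter. Among the compounds with values here, that step starts from the group entering here but does not remove methylsulfanyl, so no measured step gives the size of this change directly. The expectation rests on compound 1, which carries the entering group on its own core and gives 18.6 mg/kg. A clearly lower number than the limit of compound 3 is therefore expected in this assay, though the different core leaves its size uncertain. The estimate amounts to an expected at least 3.3-fold lower number from compound 3 to compound 4 (0.52 log units; beyond the scatter). For compound 4 the expected value is 60 mg/kg, with an estimated range from 20 mg/kg to 200 mg/kg.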

Compound 4, dose for half-maximal effect: > 200 mg/kg
Compound 4 was reported as a limit (the forecaster's own chance of this, stated with the estimate: 25%); at least 3.3-fold (0.52 log units) between middle value and limit.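

Compound 3 and compound 4 both stand at a limit in this assay, so the step between them cannot be read: the limit of > 200 mg/kg in this assay, at which 2 of the 4 values shown sit.

The compounds shown leave open whether methylsulfanyl and the group that replaces it differ at all on this core, as neither compound has a number.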